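The compounds below may be only part of what the source reports. "The series", "measured", "known", "first", "only" and "open" are said of these compounds alone.

The study rests on a shared core carried by four compounds: compound 1 `COc1ncnc2c1c(-c1ccccc1)cn2[C@@H]1O[C@H](CO)[C@@H](O)[C@H]1O`, compound 2 `CNc1ncnc2c1c(-c1ccccc1)cn2[C@@H]1O[C@H](CO)[C@@H](O)[C@H]1O`, compound 3 `COc1ncnc2c1c(-c1cc3ccccc3o1)cn2[C@@H]1O[C@H](CO)[C@@H](O)[C@H]1O` and the still unmeasured compound 4 `CNc1ncnc2c1c(-c1cc3ccccc3o1)cn2[C@@H]1O[C@H](CO)[C@@H](O)[C@H]1O`. In a functional assay on HepG2 cells (Homo sapiens) for antiproliferative activity, read by XTT assay, with a stated time of 72 h (on this read-out higher numbers stand for weaker inhibition and lower numbers for stronger inhibition), compound 1 reaches only a limit of the assay, > 20000 nM. Compound 2 likewise gives nothing beyond a limit in this assay, > 20000 nM. Compound 3 too stops at a limit in this assay, > 20000 nM. The change from compound 1 to compound 2 is methylamino in place of methoxy on an aromatic carbon; the step that the two limits leave unreadable from compound 1 to compound 2 cannot be sized because of the limit of > 20000 nM in this assay, at which 3 of the 3 values shown sit. The two cores differ by 1-benzofuran-2-yl in place of phenyl on an aromatic carbon, and the step that the two limits leave unreadable from compound 1 to compound 3 is equally unreadable for the same reason. Compound 4 carries the same change as compound 2, this time made on compound 3: methylamino in place of methoxy on an aromatic carbon. With both measured steps unreadable, the step from compound 3 to compound 4 is expected at a step that the limit leaves unreadable from compound 3 to compound 4. That expectation rests on compound 3, whose value in this assay is a limit, > 20000 nM. Compound 4 is therefore estimated to give 30000 nM, between 15000 nM and 100000 nM, most likely again as a limit.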

Compound 4, half-maximal inhibitory concentration: > 20000 nM
Compound 4: only a limit was reported; the forecaster's own chance of this, stated with the estimate: 85%; the middle value is on the limit's open side.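

No step to compound 4 from compound 2 or compound 3 can be read in this assay because the values share one limit: the limit of > 20000 nM in this assay, at which 4 of the 4 values shown sit.

The compounds shown leave open whether methylamino in place of methoxy, or 1-benzofuran-2-yl in place of phenyl, changes the read-out on the shared core at all.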